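Replacing the Dimethyloxane Group with an Isopropyloxane Group

A few compounds are considered here, and "the series" means these few. Any claim that something is new, unique, unknown or untested is made for them only; others in the source may bear on it.

Compound 1 `COc1ccccc1-n1nc(C2CCOC(C)(C)C2)cc1-c1ccc(Cl)cc1` is the reference point of this small set. In an assay on HEK293 cells for inhibition of Voltage-dependent N-type calcium channel subunit alpha-1B (Homo sapiens), read by patch clamp, using a membrane potential dye (on this read-out higher numbers stand for weaker inhibition and lower numbers for stronger inhibition), compound 1 gives 55 nM, the lowest of the three numbers. Compound 3 `CC1(C)CC(c2cc(-c3ccc(Cl)cc3)n(-c3ccccn3)n2)CC(C)(C)O1` gives 1000 nM in this assay, and compound 2 `CC1(C)CC(c2cc(-c3ccc(Cl)cc3)n(-c3ccncc3)n2)CC(C)(C)O1` gives 22000 nM. Compounds 2 and 3 differ from compound 1 at more than one place, so their gap to compound 1 cannot be assigned to a single change. Within the data shown here, the only single-point step among the measured compounds is a 22-fold lower number from compound 2 to compound 3 (1.34 log units; beyond the scatter), which concerns the group on the aromatic nitrogen and not the saturated ring.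

Compound 4 `COc1ccccc1-n1nc([C@@H]2CCO[C@H](C(C)C)C2)cc1-c1ccc(Cl)cc1` differs from compound 1 by 2-isopropyloxan-4-yl in place of 2,2-dimethyloxan-4-yl on an aromatic carbon. Among the measured compounds shown here, no measured step touches this part of the molecule, so the data give no direction for the change. A step of no more than the usual scatter is therefore expected, a 1.1-fold higher number from compound 1 to compound 4 (0.04 log units; within the scatter). Compound 4 is estimated at 60 nM in this assay, within a range of 20 nM to 200 nM.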

Compound 4, half-maximal inhibitory concentration: 55000 nM
Beside the measured number, compound 4's estimate is 920-fold (2.96 log units) below it; measured number outside the range, above it.
By their numbers in this assay, from the lowest: compound 1; then compound 3; then compound 2; then compound 4.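

Among these compounds, the position on the aromatic carbon that carries the saturated ring, which no earlier step had touched, turns out to be highly sensitive in this assay: the change to 2-isopropyloxan-4-yl gives a 1000-fold higher number from compound 1 to compound 4 (3.00 log units; beyond the scatter). This step is large even though both groups are a six-membered non-aromatic ring with one hetero atom, with the same hydrogen-bond counts and no net charge, so those shared features do not secure the activity of compound 1. Nothing available explains the size of this loss.

The compounds shown leave open whether the loss follows from the isopropyl group itself or from the two defined stereocentres of compound 4. They also leave open how the opposite stereoisomers, or a 2-methyloxan-4-yl or plain oxan-4-yl group at this position, would read out.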